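A few compounds are considered here, and "the series" means these few. Any claim that something is new, unique, unknown or untested is made for them only; others in the source may bear on it.

Working notes on the series. Compound 1 `O=C(Nc1ccc(Cl)c(-c2nnc3c(Cl)cccn23)c1)c1ccon1` carries a 1,2-oxazol-3-yl group on the carbonyl carbon; in a functional assay on HeLa cells (Homo sapiens) for antiproliferative activity, read by MTT assay, with a stated time of 72 h (a lower number here means a stronger inhibitor, a higher number a weaker inhibitor), compound 1 returns only a limit, > 100000 nM. Compound 2 `O=C(Nc1ccc(Cl)c(-c2nnc3c(Cl)cccn23)c1)c1ccc(Cl)cc1Cl` likewise returns only a limit in this assay, > 100000 nM. Going by the values given here, compound 3 `O=C(Nc1ccc(Cl)c(-c2nnc3c(Cl)cccn23)c1)c1ccccn1` is the one member with a number: in this assay compound 3 gives 75500 nM. The steps of an at least 1.3-fold lower number from compound 1 to compound 3 (0.12 log units; that floor lies within the scatter) and an at least 1.3-fold lower number from compound 2 to compound 3 (0.12 log units; that floor lies within the scatter) both start at the limit (the limit of > 100000 nM in this assay, at which 2 of the 3 values shown sit), so their floors are all that can be read, and those floors lie within the scatter. Compound 4 `O=C(Nc1ccc(Cl)c(-c2nnc3c(Cl)cccn23)c1)c1cccnc1` differs from compound 3 by pyridin-3-yl in place of pyridin-2-yl on a carbonyl carbon. Among the compounds with values here, no measured step moves a nitrogen within a single ring in this way, so the two measured steps give only a frame: one number near the limit, two values at it. The expected step of a 1.2-fold higher number from compound 3 to compound 4 (0.08 log units; within the scatter) is therefore none beyond the scatter, with a real chance that compound 4 is reported only as a limit. Compound 4 is estimated at 90000 nM, within 35000 nM to 250000 nM.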

Compound 4, half-maximal inhibitory concentration: > 100000 nM
Compound 4 ended at the assay's limit; the forecaster's own chance of this, stated with the estimate: 45%; middle value at least 1.1-fold (0.04 log units) from the limit.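

Changing pyridin-2-yl to pyridin-3-yl on a carbonyl carbon, with the same atoms joined differently, gives in this assay an at least 1.3-fold higher number from compound 3 to compound 4 (0.12 log units; that floor lies within the scatter), so this first change of nitrogen placement within a single ring yields only a floor and no size. The steps to compound 4 from compound 1 and from compound 2 cannot be read, as both ends of each are limits. Compound 3 stays the only member with a number, and the series now rests mostly on a single limit: the limit of > 100000 nM in this assay, at which 3 of the 4 values shown sit.

The compounds shown leave open whether a pyridin-4-yl group, an aminophenyl group or a short alkyl chain on this carbonyl carbon would give a number clear of the limit. They also leave open whether compound 3 and compound 4 truly differ by more than the scatter.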